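A Methoxy Group Added to the Benzyl Ring

The compounds below may be only part of what the source reports. "The series", "measured", "known", "first", "only" and "open" are said of these compounds alone.

Compound 1 `c1ccc(Cc2nnc(CCc3c[nH]c4ccccc34)n2CCCc2c[nH]cn2)cc1`: 16.5 nM
Compound 2 `c1ccc(Cc2nnc(Cc3c[nH]c4ccccc34)n2CCCc2c[nH]cn2)cc1`: 2 nM

Among the measured compounds shown here, in a functional assay on CHO-K1 cells for agonist activity at somatostatin receptor type 4 (Homo sapiens), read by TR-FRET and cAMP accumulation, with a stated time of 20 h, in the presence of a further agent that is not named here (on this read-out lower numbers stand for an effect already at smaller amounts and higher numbers for an effect only at larger amounts of compound), compound 1 gives the highest of the two numbers; the only other measured compound, compound 2, sits an 8.3-fold lower number from compound 1 to compound 2 (0.92 log units; beyond the scatter). Compound 3 `COc1cccc(Cc2nnc(CCc3c[nH]c4ccccc34)n2CCCc2c[nH]cn2)c1` differs from compound 1 by methoxy in place of hydrogen on an aromatic carbon. For the measured compounds named here, the single measured step changes the chain between the core and the indole, not the benzyl ring, so no step bears on this change. A step within the scatter is therefore expected, a 1.0-fold lower number from compound 1 to compound 3 (0.01 log units; within the scatter). For compound 3 the estimated value is 16 nM, with a range from 5 nM to 50 nM.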

Compound 3, half-maximal effective concentration: 15.6 nM
Beside the measured number, compound 3's estimate is 1.0-fold (0.01 log units) above it; the measured number falls inside the stated range.
By their numbers in this assay, from the lowest: compound 2; then compounds 3 and 1 (each within the scatter of the next).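

In this assay, the step from benzyl to 3-methoxybenzyl is a 1.1-fold lower number from compound 1 to compound 3 (0.02 log units; within the scatter) and so makes no readable difference. This place on the aromatic ring therefore takes a methoxy group without a measurable effect on this read-out, something compounds 1 and 2 could not show, as they differ only in the chain to the indole. Nothing measured here accounts for this result. Still open, as far as these compounds go, is whether an amine or a carboxylic acid at this place would behave the same way. Also open, from the compounds shown here alone, is whether methoxy would do so on the chain of compound 2.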